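Vinyl in Place of 3-Chloropropyl on an Amide Carbonyl

The compounds below may be only part of what the source reports. "The series", "measured", "known", "first", "only" and "open" are said of these compounds alone.

Compound 1 `O=C(CCCCl)Nc1ccc(I)cc1` gives in a functional assay on M21 cells (Homo sapiens) for antiproliferative activity, with a stated time of 48 h (on this read-out higher numbers stand for weaker inhibition and lower numbers for stronger inhibition), only the limit of > 100000 nM.
Compound 2 `CC(C)(C)c1ccc(CNC(=O)CCCCl)cc1` gives 69000 nM.
Compound 3 `C=CC(=O)Nc1ccc(I)cc1` gives 11000 nM.

Compound 3 differs from compound 1 by vinyl in place of 3-chloropropyl on a carbonyl carbon, and this change brings an at least 9.0-fold lower number from compound 1 to compound 3 (0.95 log units; beyond the scatter). That step is known only as a lower bound because compound 1 sits at the limit of > 100000 nM in this assay, at which 1 of the 3 values shown sits. The difference between the cores of compound 1 and compound 2 is not broken down here. Compound 4 `C=CC(=O)NCc1ccc(C(C)(C)C)cc1` is not yet measured; it differs from compound 2 by vinyl in place of 3-chloropropyl on a carbonyl carbon, the same change at the same place. The step from compound 2 to compound 4 is expected to be a 12-fold lower number from compound 2 to compound 4 (1.06 log units; beyond the scatter), resting on the step of an at least 9.0-fold lower number from compound 1 to compound 3 (0.95 log units; beyond the scatter). Compound 4 is therefore estimated at 6000 nM, likely between 1500 nM and 25000 nM.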

Compound 4, half-maximal inhibitory concentration: 72000 nM
Compound 4: middle estimate off by 12-fold (1.08 log units), on the low side, outside the stated range (above it).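

In this assay, vinyl in place of 3-chloropropyl on a carbonyl carbon brings a 1.0-fold higher number from compound 2 to compound 4 (0.02 log units; within the scatter), so on the core of compound 2 this change leaves the number where it was. The change therefore does not carry over from one core to the other with the same size: the same change on two cores in this assay, an at least 9.0-fold lower number (0.95 log units; beyond the scatter) from compound 1 to compound 3 and a 1.0-fold higher number (0.02 log units; within the scatter) from compound 2 to compound 4, at least 9.4-fold (0.97 log units) apart, beyond the scatter of two such steps These two pairs do not show which difference between the cores matters, and the earlier step remains a bound, as compound 1 is known only through a limit: the limit of > 100000 nM in this assay, at which 1 of the 4 values shown sits.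

As far as these compounds go, it remains open how an ethyl group on the carbonyl carbon would read on either core. Also open, from the compounds shown here alone, is what a 3-aminopropyl chain in the same place would give.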